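The source may hold more compounds than are shown below. What is called first, only, known or untested is meant among the compounds shown, and "the series" means these compounds.

Three measured compounds share one core and differ only in the group on the second nitrogen of that core. Compound 1 `CNc1nc(NCCCN(C)C)c2sc(-c3ccc(C(F)(F)F)cc3)cc2n1` gives 240 ug/mL in a physicochemical assay for solubility, at pH 2; on this read-out lower numbers stand for lower solubility and higher numbers for higher solubility. Compound 2 `CN(C)CCCNc1nc(N)nc2cc(-c3ccc(C(F)(F)F)cc3)sc12` gives 210 ug/mL in this assay, and compound 3 `CN(C)CCCNc1nc(N2CCNCC2)nc2cc(-c3ccc(C(F)(F)F)cc3)sc12` gives 198 ug/mL. Compound 2 stands second highest of the three numbers, yet all three lie within the scatter of one another: a 1.1-fold lower number from compound 1 to compound 2 (0.06 log units; within the scatter), a 1.2-fold lower number from compound 1 to compound 3 (0.08 log units; within the scatter) and a 1.1-fold lower number from compound 2 to compound 3 (0.03 log units; within the scatter) are each too small to count as a change.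

Compound 4 `Nc1nc(NC2CCOCC2)c2sc(-c3ccc(C(F)(F)F)cc3)cc2n1` has not yet been measured in this assay. It differs from compound 2 in one place: oxan-4-yl in place of 3-(dimethylamino)propyl on a nitrogen on an aromatic ring. Within the data shown here, none of the measured steps touches this group; all three alter the other nitrogen substituent of the core and leave the 3-(dimethylamino)propyl chain in place. So there is no measured step of the same kind to lean on, and the expectation for compound 4 rests on the structural change alone and carries a wide range.

On that basis compound 4 is expected to give 60 ug/mL in this assay, with a range from 12 ug/mL to 220 ug/mL. The estimated step of a 3.5-fold lower number from compound 2 to compound 4 (0.54 log units; beyond the scatter) is expected to fall below the value of compound 2 by more than the scatter, but the measurement is needed to confirm it.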

Compound 4, solubility: < 5 ug/mL
Compound 4: a limit, no number; the forecaster's own chance of this, stated with the estimate: 10%; at least 12-fold (1.07 log units) between middle value and limit.
By their numbers in this assay, from the lowest: compounds 3, 2 and 1 (each within the scatter of the next). At a limit, below all of these: compound 4.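

In this assay, oxan-4-yl in place of 3-(dimethylamino)propyl on a nitrogen on an aromatic ring gives an at least 42-fold lower number from compound 2 to compound 4 (1.62 log units; beyond the scatter), a large step beyond the scatter, whereas every earlier step changed the other nitrogen substituent of the core and stayed within the scatter. This shows that the read-out responds strongly to this position, even though the two groups have matching counts of heavy atoms, hydrogen-bond donors and hydrogen-bond acceptors and differ instead in a chain giving way to a six-membered non-aromatic ring and a nitrogen giving way to an oxygen. The value of compound 4 is a limit and not a number, so the full size of the step stays unknown: the limit of < 5 ug/mL in this assay, at which 1 of the 4 values shown sits.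

The single step changes the chain and the dimethylamino nitrogen together, so the compounds shown cannot say which of the two changes carries the effect. On these data alone, a 3-methoxypropyl chain or a piperidin-4-yl ring at this position would separate the two, and how either would read remains open.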